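Alkyl substitution on the shared core: compound 2 to compound 3

This account rests on a few compounds, and the source may have more. Where it says the series, first, only, none or still open, it means among the compounds named here.

Compound 1 `Nc1cnc2c(OCc3ccccc3)cccn12` is the unsubstituted parent of the series; in a functional assay on the whole organism with Canis familiaris (Canis lupus familiaris) as the target, at a dose of 8 mg/kg by the oral route (a lower number here means a weaker effect, a higher number a stronger effect of the compound at the dose given), compound 1 gives 43%. Compound 2 `CC(C)c1nc2c(OCc3ccccc3)cccn2c1N` carries an isopropyl group on the shared core, and in this assay compound 2 gives 0%. Compound 2 stands lowest of the two numbers measured, with compound 1 as its nearest neighbour, and the step of a number 43 percentage points lower from compound 1 to compound 2 (beyond the scatter) is beyond the scatter, so isopropyl in place of hydrogen on an aromatic carbon cost essentially all of the effect. Compound 3 `CCCCc1nc2c(OCc3ccccc3)cccn2c1N` continues the alkyl change: butyl in place of isopropyl on an aromatic carbon. Among the measured compounds shown here, no measured step involves butyl, so only the step from compound 1 to compound 2 bears on it, and it points to alkyl substitution at this carbon being poorly tolerated. Compound 3 is therefore expected to stay at the bottom of the range, a step of a number 5 percentage points higher from compound 2 to compound 3 (within the scatter) being expected, within the scatter. The estimated value for compound 3 in this assay is 5%, with a range from 0% to 25%.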

Compound 3, a percentage reported as inhibition, in the whole organism at one dose (the size of the read-out at that dose, not a potency): 0%
Compound 3: the middle estimate sits 5 percentage points above what was measured; the measured number falls inside the stated range.
By their numbers in this assay, from the lowest: compounds 2 and 3 (each within the scatter of the next); then compound 1.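

In this assay, the loss is not confined to isopropyl: butyl on the same aromatic carbon gives a number 43 percentage points lower from compound 1 to compound 3 (beyond the scatter), while exchanging isopropyl for butyl gives no change at the digits printed from compound 2 to compound 3 (within the scatter). Both alkyl groups at this carbon therefore stand well apart from the hydrogen of compound 1, and this pair offers no separation between them, as compound 2 and compound 3 share the same printed number. No supporting information bears on the reason for this loss.

Still open, going by these compounds, is whether a group smaller than isopropyl, such as methyl, keeps any of the effect of compound 1 at this carbon. Also open, on these data alone, is how a chain ending in an amine or a carboxylic acid would fare at the same place.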